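Phenyl in place of cycloheptyl on a sulfated sugar amide

The compounds below may be only part of what the source reports. "The series", "measured", "known", "first", "only" and "open" are said of these compounds alone.

Compound 1, `CO[C@H]1O[C@H](CNC(=O)CN(Cc2ccccc2)C(C)=O)[C@@H](OS(=O)(=O)O)[C@H](OS(=O)(=O)O)[C@@H]1OS(=O)(=O)O`, gives 140000 nM in an assay on isolated protein for binding affinity to fibroblast growth factor 1 (Homo sapiens), read by surface plasmon resonance; on this read-out higher numbers stand for weaker binding and lower numbers for tighter binding.
Compound 2, `CO[C@H]1O[C@H](CNC(=O)CN(C(C)=O)C2CCCCCC2)[C@@H](OS(=O)(=O)O)[C@H](OS(=O)(=O)O)[C@@H]1OS(=O)(=O)O`, gives 370000 nM in this assay.

Both compounds share the same sulfated sugar core and differ only in the group on an amide-type nitrogen. Within the data shown here, compound 2 holds the higher of the two numbers, meaning weaker binding; its only neighbour is compound 1, and the step of a 2.6-fold higher number from compound 1 to compound 2 (0.42 log units; beyond the scatter) lies beyond the scatter. Compound 3, `CO[C@H]1O[C@H](CNC(=O)CN(C(C)=O)c2ccccc2)[C@@H](OS(=O)(=O)O)[C@H](OS(=O)(=O)O)[C@@H]1OS(=O)(=O)O`, has not yet been measured; it differs from compound 2 by phenyl in place of cycloheptyl on an amide-type nitrogen. Among the measured compounds shown here, the one measured step that bears on this is a 2.6-fold higher number from compound 1 to compound 2 (0.42 log units; beyond the scatter), a modest loss on going from benzyl to cycloheptyl. Phenyl resembles benzyl more than cycloheptyl, so a modest recovery is expected, though it may stay within the scatter. Compound 3 is therefore estimated at 200000 nM, with a range from 80000 nM to 500000 nM. That estimate means an expected step of a 1.9-fold lower number from compound 2 to compound 3 (0.27 log units; within the scatter).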

Compound 3, dissociation constant: 196000 nM
Beside the measured number, compound 3's estimate is 1.0-fold (0.01 log units) above it; low and high end bracket the measured number.
By their numbers in this assay, from the lowest: compounds 1, 3 and 2 (each within the scatter of the next, the first and the last beyond it).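

Placing phenyl on the amide-type nitrogen gives a 1.9-fold lower number from compound 2 to compound 3 (0.28 log units; within the scatter) in this assay and, set against benzyl, gives a 1.4-fold higher number from compound 1 to compound 3 (0.15 log units; within the scatter) in the same test. Neither step clears the scatter, so phenyl cannot be told apart from cycloheptyl or from benzyl at this position, even though benzyl and cycloheptyl can be told apart from each other. No evidence is at hand to explain these numbers.

As far as these compounds go, what a phenyl ring carrying an amine or a carboxylic acid would do on this nitrogen stays open, as does the effect of a longer chain such as phenethyl. Also open, from the compounds shown here alone, is whether any group here can move the number further than the modest 2.6-fold higher number from compound 1 to compound 2 (0.42 log units; beyond the scatter) seen so far.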